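A few compounds are considered here, and "the series" means these few. Any claim that something is new, unique, unknown or untested is made for them only; others in the source may bear on it.

Compound 1 `CCCC(=O)N1CC2CC(C1)N2` carries a propyl group on the carbonyl carbon of the shared core, and in an assay on CHO cells for agonist activity at Neuronal acetylcholine receptor; alpha3/alpha6/beta2/beta3 (Homo sapiens), read by FLIPR and calcium flux (on this read-out higher numbers stand for larger maximal responses and lower numbers for smaller maximal responses), compound 1 gives 92%. Compound 2 `O=C([C@H]1C[C@H]1F)N1CC2CC(C1)N2` and compound 3 `O=C([C@H]1C[C@@H]1F)N1CC2CC(C1)N2` each carry a 2-fluorocyclopropyl group in place of propyl on the carbonyl carbon and differ only in the configuration of one stereocentre at a saturated ring carbon. In this assay compound 2 gives 130%, while compound 3 gives 85%. The step of a number 38 percentage points higher from compound 1 to compound 2 (beyond the scatter) was large, whereas the step of a number 7 percentage points lower from compound 1 to compound 3 (within the scatter) stayed within the scatter, so compound 3 lies within the scatter of compound 1 and stands well below compound 2, as the step of a number 45 percentage points lower from compound 2 to compound 3 (beyond the scatter) shows.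

Compound 4 `C[C@H]1C[C@@H]1C(=O)N1CC2CC(C1)N2` changes compound 3 at one place: methyl in place of fluoro on a saturated ring carbon. For the measured compounds named here, none of the measured steps exchanges fluoro for methyl on the three-membered ring, so they bear only indirectly on this change. Given that compound 3 itself sits near compound 1 at 92%, the expectation for compound 4 is a step of a number 5 percentage points higher from compound 3 to compound 4 (within the scatter), that is none beyond the scatter. Compound 4 is therefore estimated at 90%, with a range from 65% to 120%.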

Compound 4, largest response reached (Emax), in percent of the reference or control that the assay uses: 64%
Beside the measured number, compound 4's estimate is 26 percentage points above it, and the stated range ends above it.
By their numbers in this assay, from the lowest: compound 4; then compounds 3 and 1 (each within the scatter of the next); then compound 2.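

Exchanging fluoro for methyl at this saturated ring carbon gives a number 21 percentage points lower from compound 3 to compound 4 (beyond the scatter) in this assay and is a modest step, so this one-atom change moves the maximal response. Compound 3 stood within the scatter of compound 1, but the methyl analogue does not: 2-methylcyclopropyl in place of propyl gives a number 28 percentage points lower from compound 1 to compound 4 (beyond the scatter) and places a substituted cyclopropyl clearly below the open chain. Set against compound 2, the change gives a number 66 percentage points lower from compound 2 to compound 4 (beyond the scatter) as a large step, so the group on the carbonyl carbon alone spans the highest and lowest of the four compounds.

Still open, from the compounds shown here alone, is how a chlorine, hydroxyl or trifluoromethyl group on the same ring carbon would compare with fluoro and methyl. The compounds shown offer no measured reason for the fall at compound 4.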